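A few compounds are considered here, and "the series" means these few. Any claim that something is new, unique, unknown or untested is made for them only; others in the source may bear on it.

Compound 1 `COc1ccc2nc(C)cc(NCc3ccc(C(F)(F)F)cc3)c2c1`: 7600 nM
Compound 2 `COc1ccc2nc(C)cc(NCc3ccc(F)cc3C(F)(F)F)c2c1`: 5200 nM

In a functional assay on MCF-10A cells (Homo sapiens) for antiproliferative activity, with a stated time of 48 h (a higher number here means that more compound is needed for the effect, a lower number that less compound is needed), compound 1 gives 7600 nM and compound 2 gives 5200 nM. For the measured compounds named here, these are the only two numbers so far, and they lie within the usual scatter of each other, so compound 1 cannot be ranked against compound 2. Both sit in the same region of the scale.

The next compound to be tested is compound 3 `COc1ccc2nc(C)cc(NCc3ccc(N(C)C)cc3)c2c1`. It keeps the core of compound 1 and carries dimethylamino in place of trifluoromethyl on an aromatic carbon, para to a large group: dimethylamino in place of trifluoromethyl on an aromatic carbon.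

Going by the values given here, no measured pair shows what this swap does, so any forecast rests on thin evidence. With compound 1 at 7600 nM as the starting point, the expectation in this assay is no step beyond the scatter, and no firm direction can be given. The estimated change is a 1.3-fold lower number from compound 1 to compound 3 (0.10 log units; within the scatter), and a wide margin on either side is expected to be needed. For compound 3 the expected value is 6000 nM, with an estimated range from 2000 nM to 18000 nM.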

Compound 3, half-maximal effective concentration: 15100 nM
For compound 3 the middle estimate is 2.5-fold (0.40 log units) below the measured one, within the range that was stated.
By their numbers in this assay, from the lowest: compounds 2, 1 and 3 (each within the scatter of the next, the first and the last beyond it).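

Read in this assay with the core of compound 1 kept intact, dimethylamino in place of trifluoromethyl on an aromatic carbon, para to a large group, gives a 2.0-fold higher number from compound 1 to compound 3 (0.30 log units; within the scatter) and provides the first measured step at this position. The earlier compounds shown here could not show this, and the step means that these two groups, which share no atoms other than carbon and differ in hydrogen-bond acceptors, cannot be told apart in this read-out, so no direction can be assigned to the change. Nothing measured here bears on how either group acts on these cells.

One pair at one position cannot show whether this position tolerates nearly any group or whether these two simply happen to give similar numbers. A nitrile, a carboxylic acid or a longer chain at the same place would test this, and a primary amine would show whether the two methyl-bearing carbons of dimethylamino matter to the number at all.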